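The source may report more compounds than this note shows. Statements on the series, on what has been measured and on what is new or still open speak of the compounds shown alone.

Measured in an ADME assay on HT-29 cells (Homo sapiens) for cytotoxicity, read by MTT assay, with a stated time of 72 h (on this read-out higher numbers stand for weaker inhibition and lower numbers for stronger inhibition), where each entry is a limit of the assay and not a number:

- compound 1 `COc1ccc(C2=C(c3cc(OC)c(OC)c(OC)c3)C(=O)CC2C)cc1C(=O)O`: > 100 ug/mL
- compound 2 `C=CCOc1cc(C2=C(c3cc(OC)c(OC)c(OC)c3)C(=O)C(O)C2)ccc1OC`: > 100 ug/mL
- compound 3 `COC(=O)c1cc(C2=C(c3cc(OC)c(OC)c(OC)c3)C(=O)CC2O[SiH2]C(C)(C)C)ccc1OC`: > 100 ug/mL

Compound 2 has no exact number and stands at the limit of > 100 ug/mL in this assay, at which 3 of the 3 values shown sit. Compound 4 `COc1ccc(C2=C(c3cc(OC)c(OC)c(OC)c3)C(=O)C(O)C2)cc1Cl` is compound 2 with chloro in place of allyloxy on an aromatic carbon. Going by the values given here, no two measured compounds differ in one place only, so the size of this change cannot be read from a measured step. Compound 2 rests at > 100 ug/mL, which is a limit, so any number measured for compound 4 would lie on the stronger side. The expected at least 3.3-fold lower number from compound 2 to compound 4 (0.52 log units; beyond the scatter) therefore points toward stronger inhibition, with its size quite uncertain. The estimate for compound 4 is 30 ug/mL, with an expected range from 2 ug/mL to 100 ug/mL.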

Compound 4, half-maximal inhibitory concentration: < 1 ug/mL
Compound 4: a limit, no number; the forecaster's own chance of this, stated with the estimate: 45%; middle value at least 30-fold (1.47 log units) away from the limit.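

In this assay, chloro in place of allyloxy on an aromatic carbon, ortho to a methoxy group, gives an at least 100-fold lower number from compound 2 to compound 4 (2.00 log units; beyond the scatter). Compound 4 alone leaves the upper limit shared by the other compounds, and its own value is also a limit: the limit of < 1 ug/mL in this assay, at which 1 of the 4 values shown sits. This position therefore responds strongly to a single change of group, though the exact size of the step cannot be read from two limits.

On these data alone, it remains open whether the gain comes from having chloro or from losing allyloxy. Fluoro, bromo or a small methyl group at this position could help separate the two.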